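A few compounds are considered here, and "the series" means these few. Any claim that something is new, unique, unknown or untested is made for them only; others in the source may bear on it.

Measured compounds:
compound 1 `CN1CCN(c2nc(-c3cccc(O)c3)nc3c2ncn3C)CC1`: in an assay on cells for displacement of a labelled ligand from adenosine receptor A1 (Homo sapiens), read by scintillation counting and radioligand binding, with a stated time of 60 min, tested at 10 uM (on this read-out higher numbers stand for more inhibition at the one concentration tested (going by the name of the read-out) and lower numbers for less inhibition), compound 1 gives 27.1%.
compound 2 `CN1CCN(c2nc(-c3cccc(Cl)c3)nc3[nH]cnc23)CC1`: in this assay compound 2 gives > 80%, a limit of the assay and not a number.
compound 3 `CN1CCN(c2nc(-c3cccc(O)c3)nc3[nH]cnc23)CC1`: in this assay compound 3 gives > 80%, a limit of the assay and not a number.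

On these data alone, compound 2 thus stands at the limit of > 80% in this assay, at which 2 of the 3 values shown sit, so its true read-out is unknown. Compound 4 `CN1CCN(c2nc(-c3cccc(Cl)c3)nc3c2ncn3C)CC1` differs from compound 2 by methyl in place of hydrogen on an aromatic nitrogen. The reverse of this change has been measured once: a number at least 52.9 percentage points higher from compound 1 to compound 3 (beyond the scatter). Run backwards, it points to a large fall, though the limit hides its full size. The step that the two limits leave unreadable from compound 2 to compound 3 concerns a different change and does not bear on it. Compound 4 is therefore expected to lose much of the inhibition seen for compound 2, the estimated step being a number at least 50 percentage points lower from compound 2 to compound 4 (beyond the scatter). Compound 4 is estimated at 30%, with a range of 10% to 55%.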

Compound 4, a percentage reported as inhibition, at one concentration (the size of the read-out at that concentration, not a potency): 45.7%
For compound 4 the middle estimate is 15.7 percentage points below the measured one, and the stated range covers the measured number.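

Methyl in place of hydrogen on the aromatic nitrogen also lowers the read-out in this assay when chloro replaces hydroxy on the aromatic carbon, giving a number at least 34.3 percentage points lower from compound 2 to compound 4 (beyond the scatter). The fall is therefore not confined to the hydroxy pair, and the change points the same way on two cores: the same change on two cores in this assay, a number at least 52.9 percentage points higher (beyond the scatter) from compound 1 to compound 3 and a number at least 34.3 percentage points higher (beyond the scatter) from compound 4 to compound 2; the limit leaves it open whether they differ. With methyl on that nitrogen, the aromatic carbon position also becomes readable, with a number 18.6 percentage points higher from compound 1 to compound 4 (beyond the scatter).

Compound 2 and compound 3 both sit at a limit of the assay, so the step between them cannot be read. On these data alone, how an ethyl chain on that nitrogen, or an amine or a carboxylic acid on that aromatic carbon, would read remains open.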